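Capping the free hydroxymethyl of compound 2

A few compounds are considered here, and "the series" means these few. Any claim that something is new, unique, unknown or untested is made for them only; others in the source may bear on it.

In a functional assay on MCF7 cells (Homo sapiens) for cytotoxicity, read by MTT assay, with a stated time of 4 h (a lower number here means a stronger inhibitor, a higher number a weaker inhibitor), compound 1 (`COC(=O)C1=CO[C@@H](O[C@@H]2O[C@H](COC(c3ccccc3)(c3ccccc3)c3ccccc3)[C@@H](O)[C@H](O)[C@H]2O)[C@@H]2[C@@H](C)[C@@H](O)C[C@H]12`) gives 1 ug/mL as its half-maximal inhibitory concentration. Compound 2 (`COC(=O)C1=CO[C@@H](O[C@@H]2O[C@H](CO)[C@@H](OC(C)=O)[C@H](OC(C)=O)[C@H]2OC(C)=O)[C@@H]2[C@@H](C)[C@@H](OC(C)=O)C[C@H]12`) has no number to place on that scale and is reported as "not active" (no number reported) without a figure. Compound 3 (`CCCCCCCCCCCCCCCC(=O)OC[C@H]1O[C@@H](O[C@@H]2OC=C(C(=O)OC)[C@H]3C[C@H](OC(C)=O)[C@H](C)[C@@H]23)[C@H](OC(C)=O)[C@@H](OC(C)=O)[C@@H]1OC(C)=O`) is likewise reported as "not active" (no number reported) without a figure. Compound 4 (`COC(=O)C1=CO[C@@H](O[C@@H]2O[C@H](COC(=O)C=C(C)C)[C@@H](OC(C)=O)[C@H](OC(C)=O)[C@H]2OC(C)=O)[C@@H]2[C@@H](C)[C@@H](OC(C)=O)C[C@H]12`) arises from compound 2 through one change: (2-methylprop-1-en-1-yl)carbonyl in place of hydrogen on an oxygen on a saturated carbon (the hydroxymethyl becomes (((2-methylprop-1-en-1-yl)carbonyl)oxy)methyl). For the measured compounds named here, no measured step shows the size of such a change in this assay. Going by the values given here, with compound 2 at "not active" (no number reported) and compound 3 at "not active" (no number reported) as the guides, the expectation is little or no step towards stronger inhibition, and compound 4 may well be reported without a number too. Should a number appear, it is expected on the weaker side of compound 1 at 1 ug/mL in this assay. Compound 4 is estimated at 50 ug/mL in that case, with an expected range from 10 ug/mL to 200 ug/mL for the measurement.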

Compound 4, half-maximal inhibitory concentration: 1 ug/mL
Compound 4: the middle estimate sits 50-fold (1.70 log units) above what was measured, and the stated range ends above it.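

In this assay, for the compounds shown here, compound 2 has no number, and compound 4 gives 1 ug/mL, so no step between them can be read. The compounds shown leave open how large the effect of this change on the hydroxymethyl is. No measurement here accounts for the result.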